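A few compounds are considered here, and "the series" means these few. Any claim that something is new, unique, unknown or untested is made for them only; others in the source may bear on it.

- compound 1 `COc1ccc(C#Cc2cc(Cl)cn3c([N+](=O)[O-])c(CS(=O)(=O)c4ccccc4)nc23)cc1`: > 3900 nM (a limit)
- compound 2 `COc1cccc(C#Cc2cc(Cl)cn3c([N+](=O)[O-])c(CS(=O)(=O)c4ccccc4)nc23)c1`: > 3900 nM (a limit)
- compound 3 `COc1ccccc1C#Cc1cc(Cl)cn2c([N+](=O)[O-])c(CS(=O)(=O)c3ccccc3)nc12`: > 3900 nM (a limit)

These values come from an ADME assay on HepG2 cells (Homo sapiens) for cytotoxicity, read by MTT assay, with a stated time of 72 h; on this read-out higher numbers stand for lower toxicity in this test and lower numbers for higher toxicity in this test. Compound 3 stands at > 3900 nM, which is a limit of the assay and not a number. Going by the values given here, the same holds for the whole series so far, which gives (the limit of > 3900 nM in this assay, at which 3 of the 3 values shown sit).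

Compound 4 `O=[N+]([O-])c1c(CS(=O)(=O)c2ccccc2)nc2c(C#Cc3ccc(F)cc3)cc(Cl)cn12` carries 4-fluorophenyl in place of 2-methoxyphenyl on a triple-bonded carbon.

The nearest measured changes only move the methoxy group around the phenyl ring: a step that the two limits leave unreadable from compound 1 to compound 2, a step that the two limits leave unreadable from compound 1 to compound 3 and a step that the two limits leave unreadable from compound 2 to compound 3. None of them has a readable size, and none brings in fluorine. They therefore offer no direction or size to carry over. All three methoxyphenyl compounds sit at one limit, so the expectation in this assay is no step beyond the scatter, with compound 4 most likely reported as a limit too.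

The expected change is a step that the limit leaves unreadable from compound 3 to compound 4. For compound 4 the estimated value is 6000 nM, with an expected range from 2500 nM to 30000 nM.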

Compound 4, half-maximal cytotoxic concentration: > 3900 nM
Compound 4 was reported as a limit; the forecaster's own chance of this, stated with the estimate: 75%; the middle value does not contradict the limit.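

Compound 4, like compound 1, compound 2 and compound 3, is reported only as a limit and not a number, so no step among these compounds can be read: the limit of > 3900 nM in this assay, at which 4 of the 4 values shown sit. In this assay the compounds shown leave open whether 4-fluorophenyl and the methoxyphenyl groups differ at all.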